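The source may hold more compounds than are shown below. What is called first, only, known or untested is meant among the compounds shown, and "the series" means these compounds.

For the measured compounds named here, in a functional assay on MCF7 cells (Homo sapiens) for antiproliferative activity, read by MTT assay, with a stated time of 72 h (a lower number here means a stronger inhibitor, a higher number a weaker inhibitor), two close relatives have numbers so far. Compound 1 `Cc1ccc(N(C)S(=O)(=O)C2CC3OC2C(c2ccc(NC(=O)CCCCCCC(=O)O)cc2)=C3c2ccc(O)cc2)cc1` gives 23200 nM, and compound 2 `CCN(c1ccc(C)cc1)S(=O)(=O)C1CC2OC1C(c1ccc(NC(=O)CCCCCCC(=O)O)cc1)=C2c1ccc(O)cc1` gives 42300 nM. Going by the values given here, compound 1 is the only neighbour by which compound 2 can be placed, and the two values lie within the scatter of each other. Compound 3 `CCN(c1ccc(Cl)cc1)S(=O)(=O)C1CC2OC1C(c1ccc(NC(=O)CCCCCCC(=O)O)cc1)=C2c1ccc(O)cc1` keeps the rest of compound 2 and alters one substituent: chloro in place of methyl on an aromatic carbon, para to a large group, so that 4-methylphenyl becomes 4-chlorophenyl (chloro in place of methyl on an aromatic carbon). Among the compounds with values here, no measured step covers this exchange directly. Within the data shown here, the only measured step, a 1.8-fold higher number from compound 1 to compound 2 (0.26 log units; within the scatter), is methyl in place of hydrogen on a saturated chain carbon bound to a sulfonamide nitrogen, which is a different place in the molecule, and it stayed within the scatter. That single step gives little guidance, so no change beyond the scatter is expected in this assay, and no direction is firmly predicted. The step expected from the estimate is a 1.2-fold lower number from compound 2 to compound 3 (0.08 log units; within the scatter). For compound 3 the estimated value is 35000 nM, with an expected range of 15000 nM to 80000 nM.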

Compound 3, half-maximal inhibitory concentration: 22100 nM
Compound 3: middle estimate off by 1.6-fold (0.20 log units), on the high side, and the stated range covers the measured number.
By their numbers in this assay, from the lowest: compounds 3, 1 and 2 (each within the scatter of the next).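

In this assay, for the compounds shown here, chloro in place of methyl on an aromatic carbon, para to a large group, gives a 1.9-fold lower number from compound 2 to compound 3 (0.28 log units; within the scatter) and so provides the first measured exchange at this position. The earlier step concerned a different place in the molecule, and the new result shows that this exchange also stays within the scatter. With both places differing, (4-chlorophenyl)(ethyl)amino in place of methyl(4-methylphenyl)amino gives a 1.0-fold lower number from compound 1 to compound 3 (0.02 log units; within the scatter) and so the three compounds, read in pairs, all lie within the scatter of one another; no measurement here speaks to the reason for these numbers.

With only methyl and chloro shown on this aromatic carbon, it remains open whether fluoro, bromo, methoxy, nitrile or an amine there would give a number beyond the scatter. From the compounds shown here alone, it also remains open whether a propyl chain in place of the ethyl on compound 3 would do so, since these three compounds show no step beyond the scatter in either place.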